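Fluoro for chloro on the benzyl group

The source may hold more compounds than are shown below. What is called first, only, known or untested is meant among the compounds shown, and "the series" means these compounds.

In an ADME assay on MT4 cells (Homo sapiens) for cytotoxicity, read by MTT assay (a higher number here means that more compound is tolerated, a lower number that less compound is tolerated), compound 1 (`Cc1c(Cc2c(F)cccc2Cl)nc(SCC(=O)c2ccc(F)cc2)[nH]c1=O`) gives > 59000 nM as a limit of the assay and not a number. Compound 2 (`COc1ccc(C(=O)CSc2nc(Cc3c(F)cccc3Cl)c(C)c(=O)[nH]2)cc1`) gives > 12000 nM which is likewise a limit. Compound 3 (`COc1ccc(C(=O)CSc2nc(Cc3c(F)cccc3Cl)c(C(C)C)c(=O)[nH]2)cc1`) gives > 11000 nM which is also a limit. Compound 2 therefore stands on a limit, as do the other two values, and no order among them can be read.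

Compound 4 (`COc1ccc(C(=O)CSc2nc(Cc3c(F)cccc3F)c(C)c(=O)[nH]2)cc1`) differs from compound 2 by one exchange (fluoro in place of chloro on an aromatic carbon) that turns 2-chloro-6-fluorobenzyl into 2,6-difluorobenzyl. The measured steps offer little guidance. The methoxy change is a step that the two limits leave unreadable from compound 1 to compound 2 and the isopropyl change is a step that the two limits leave unreadable from compound 2 to compound 3 and neither touches the chloro. Within the data shown here, no measured step therefore supports a shift, and another limit is the likeliest report. The step expected is a step that the limit leaves unreadable from compound 2 to compound 4 and no larger than the scatter. For compound 4 the estimate is 15000 nM with an expected span from 5000 nM to 60000 nM as its range.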

Compound 4, half-maximal cytotoxic concentration: > 60000 nM
Compound 4 gave a limit, no number; the forecaster's own chance of this, stated with the estimate: 80%; middle value at least 4.0-fold (0.60 log units) away from the limit.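

Compound 2 and compound 4 both give a limit and not a number, so the exchange of chloro for fluoro yields no readable step. The compounds shown leave open where the true half-maximal cytotoxic concentration of any of the four lies in this assay, and whether any single exchange shifts it.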